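The source may hold more compounds than are shown below. What is called first, only, known or untested is meant among the compounds shown, and "the series" means these compounds.

Compound 1 `CS(=O)(=O)NNc1nonc1/C(=N/O)Nc1ccc(F)c(Br)c1` — in an assay on HeLa cells for inhibition of Indoleamine 2,3-dioxygenase 1 (Homo sapiens), read by spectrophotometry, with a stated time of 24 h (a lower number here means that less compound is needed, a higher number that more compound is needed for the effect), compound 1 gives > 800 nM, which is a limit of the assay and not a number.
Compound 2 `[O-][S+]1CC(Nc2nonc2/C(=N/O)Nc2ccc(F)c(Br)c2)C1` — in this assay compound 2 gives 79 nM.
Compound 3 `O=S1(=O)CC(Nc2nonc2/C(=N/O)Nc2ccc(F)c(Br)c2)C1` — in this assay compound 3 gives 59 nM.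

Compound 3 stands at the lowest of the two numbers, yet its nearest neighbour, compound 2, lies within the scatter of it: a 1.3-fold lower number from compound 2 to compound 3 (0.13 log units; within the scatter). The steps from the open chain of compound 1 to either four-membered ring are larger, an at least 10-fold lower number from compound 1 to compound 2 (1.00 log units; beyond the scatter) and an at least 13-fold lower number from compound 1 to compound 3 (1.13 log units; beyond the scatter). The value of compound 1 is only a limit (the limit of > 800 nM in this assay, at which 1 of the 3 values shown sits).

Compound 4 `N=S1(=O)CC(Nc2nonc2/C(=N/O)Nc2ccc(F)c(Br)c2)C1` has not been measured. It differs from compound 3 by a group of 6 heavy atoms (3 carbon, 1 nitrogen, 1 oxygen, 1 sulfur; one four-membered non-aromatic ring with 1 hetero atom) in place of a group of 6 heavy atoms (3 carbon, 2 oxygen, 1 sulfur; one four-membered non-aromatic ring with 1 hetero atom), on a nitrogen on an aromatic ring; one hydrogen-bond donor enters where the leaving group had none, while the hydrogen-bond acceptors stay at two. For the measured compounds named here, the one measured step that bears on this exchange within the ring is a 1.3-fold lower number from compound 2 to compound 3 (0.13 log units; within the scatter), which stayed within the scatter. The step from compound 3 to compound 4 is therefore expected to be a 1.0-fold higher number from compound 3 to compound 4 (0.01 log units; within the scatter), none beyond the scatter. Compound 4 is expected to give 60 nM in this assay, within a range from 25 nM to 150 nM.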

Compound 4, half-maximal effective concentration: 53 nM
Compound 4: the middle estimate sits 1.1-fold (0.05 log units) above what was measured, and the stated range covers the measured number.
By their numbers in this assay, from the lowest: compounds 4, 3 and 2 (each within the scatter of the next). At a limit, above all of these: compound 1.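

On this nitrogen on an aromatic ring, a hydrogen-bond donor enters without separating the numbers in this assay, with a 1.1-fold lower number from compound 3 to compound 4 (0.05 log units; within the scatter), and the other ring comparison reads the same way, with a 1.5-fold lower number from compound 2 to compound 4 (0.17 log units; within the scatter). Compound 4 therefore joins compound 2 and compound 3 as a third four-membered ring with sulfur that the assay does not tell apart, whereas the open-chain group of compound 1 stays clearly separate, with an at least 15-fold lower number from compound 1 to compound 4 (1.17 log units; beyond the scatter). Compound 1 is known only through a limit of the assay: the limit of > 800 nM in this assay, at which 1 of the 4 values shown sits.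

The compounds shown leave open whether a four-membered ring without sulfur, such as cyclobutane or oxetane, would give similar numbers. They also leave open whether a methyl group on the ring nitrogen of compound 4 would stay within the scatter of it.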